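The compounds below may be only part of what the source reports. "The series", "measured", "known", "first", "only" and "open" are said of these compounds alone.

Series notes. Compound 1 `COc1ccccc1/C=C/C(=O)/C=C/c1ccc(OCc2cn(CCCCOc3cc(=O)oc4ccccc34)nn2)c(OC)c1` and compound 2 `COc1ccc(/C=C/C(=O)/C=C/c2ccc(OCc3cn(CCOc4cc(=O)oc5ccccc45)nn3)c(OC)c2)cc1OC` have both been run in a functional assay on THP-1 cells (Homo sapiens) for inhibition, read by sulforhodamine B assay, with a stated time of 48 h, tested at 50 uM; on this read-out lower numbers stand for less inhibition of growth and higher numbers for more inhibition of growth at the one concentration tested; compound 1 gives 40% and compound 2 gives 90%. Compound 2 stands highest of the two numbers, and the gap to compound 1 lies beyond the usual scatter, although the two compounds differ in more than one place, so the gap cannot be tied to a single change. Compound 3 `COc1cccc(/C=C/C(=O)/C=C/c2ccc(OCc3cn(CCOc4cc(=O)oc5ccccc45)nn3)c(OC)c2)c1` is not yet measured in this assay; against compound 2 the change is hydrogen in place of methoxy on an aromatic carbon, 3,4-dimethoxyphenyl becoming 3-methoxyphenyl. Going by the values given here, with no single-change step to lean on, a moderate loss of growth inhibition is expected, a number 25 percentage points lower from compound 2 to compound 3 (beyond the scatter). Compound 3 is estimated at 65%, with a range of 35% to 90%.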

Compound 3, percent growth inhibition at one concentration: 77%
For compound 3 the middle estimate is 12 percentage points below the measured one, and the stated range covers the measured number.
By their numbers in this assay, from the lowest: compound 1; then compound 3; then compound 2.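

Going by these compounds alone, the first single-change step reads in this assay: hydrogen in place of methoxy, 3,4-dimethoxyphenyl becoming 3-methoxyphenyl, gives a number 13 percentage points lower from compound 2 to compound 3 (beyond the scatter) and so a modest loss beyond the scatter. Removing this methoxy therefore costs only part of the growth inhibition, and compound 3 still gives 77% with the remaining methoxy in place. No measurement here explains the step.

Open, as far as these compounds go, is how a hydroxy group, an amine or a carboxylic acid at this aromatic carbon would compare with methoxy and hydrogen. Also open, from the compounds shown here alone, is what removing the remaining methoxy would do.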